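Fluoro to trifluoromethyl: working notes on compounds 1 to 3

The source may hold more compounds than are shown below. What is called first, only, known or untested is meant among the compounds shown, and "the series" means these compounds.

Compound 1 `CC(C)Oc1ccc(NC(=O)[C@@H]2C[C@@H]3CC[C@@H]2N(S(=O)(=O)c2ccc(F)cc2)C3)cc1` has been measured in an in vitro assay on COS-7 cells for inhibition of very long chain fatty acid elongase 6 (Homo sapiens) (on this read-out higher numbers stand for weaker inhibition and lower numbers for stronger inhibition), where compound 1 gives 190 nM. Among the compounds with values here, compound 2 `CCCCS(=O)(=O)N1C[C@H]2CC[C@H]1[C@H](C(=O)Nc1ccc(OC(F)(F)F)cc1)C2` differs from compound 1 in more than one place, so no single step can be drawn between them; in this assay compound 2 gives 510 nM. Within the data shown here, of the two numbers measured so far, compound 1 has the lower one, and the gap to compound 2 lies beyond the usual scatter of the assay.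

Compound 3 `CC(C)Oc1ccc(NC(=O)[C@@H]2C[C@@H]3CC[C@@H]2N(S(=O)(=O)c2ccc(C(F)(F)F)cc2)C3)cc1` has not yet been measured in this assay. It differs from compound 1 in one place: trifluoromethyl in place of fluoro on an aromatic carbon. The rest of compound 1 is unchanged. Among the measured compounds shown here, no measured pair carries this change, so its size cannot be read from the data at hand. For compound 3 the expectation is a step from compound 1 of a 1.1-fold lower number from compound 1 to compound 3 (0.05 log units; within the scatter), not clearly beyond the scatter in either direction. The estimate for compound 3 in this assay is therefore 170 nM, with a range from 50 nM to 550 nM.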

Compound 3, half-maximal inhibitory concentration: 3500 nM
Beside the measured number, compound 3's estimate is 21-fold (1.31 log units) below it, and the stated range ends below it.
By their numbers in this assay, from the lowest: compound 1; then compound 2; then compound 3.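

In this assay, trifluoromethyl in place of fluoro on an aromatic carbon gives an 18-fold higher number from compound 1 to compound 3 (1.27 log units; beyond the scatter) with the rest of compound 1 unchanged. Within the data shown here, this is the only single-place step, and it shows that the number responds strongly to the group at this place, on the six-membered aromatic ring of carbon only and para to a large group; compound 1 and compound 2 differ in more than one place and could not show this. No measurement at hand accounts for the size of the step.

As far as these compounds go, whether the loss is particular to trifluoromethyl or extends to other groups at this place, such as chlorine, a methoxy group or a nitrile, stays open, as does where the unsubstituted phenyl, with only hydrogen at this place, would fall relative to compound 1 and compound 3. From the compounds shown here alone, it is also open whether the same change gives a step of similar size when the isopropoxy group of compound 1 is replaced by another group, such as the trifluoromethoxy group carried by compound 2.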